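The source may report more compounds than this note shows. Statements on the series, on what has been measured and on what is new or still open speak of the compounds shown alone.

In a functional assay on OVCAR-3 cells (Homo sapiens) for antiproliferative activity, read by spectrophotometry, with a stated time of 2 days (a higher number here means a weaker inhibitor of growth, a lower number a stronger inhibitor of growth), three compounds sharing one core have been tested: compound 1 (`COc1ccc(C(F)(F)F)cc1Nc1ncc(C(F)(F)F)c(N2Cc3cccc(N(C)S(C)(=O)=O)c3C2)n1`), compound 2 (`Cc1cc(C)cc(Nc2ncc(C(F)(F)F)c(N3Cc4cccc(N(C)S(C)(=O)=O)c4C3)n2)c1`) and compound 3 (`COc1cc(Nc2ncc(C(F)(F)F)c(N3Cc4cccc(N(C)S(C)(=O)=O)c4C3)n2)cc(C(F)(F)F)c1`). Compound 1 gives > 30000 nM as a limit of the assay and not a number. Compound 2 gives > 30000 nM as a limit too. Compound 3 gives > 30000 nM as a limit as well. Compound 3 therefore has no number of its own, and the whole set sits at one limit (the limit of > 30000 nM in this assay, at which 3 of the 3 values shown sit).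

Compound 4 (`CN(c1cccc2c1CN(c1nc(Nc3cccc(C(F)(F)F)c3)ncc1C(F)(F)F)C2)S(C)(=O)=O`) differs from compound 3 in a single place (hydrogen in place of methoxy on an aromatic carbon). Hydrogen stands in place of methoxy on an aromatic carbon, meta to a trifluoromethyl group, so that 3-methoxy-5-(trifluoromethyl)phenyl becomes 3-(trifluoromethyl)phenyl.

Three measured steps alter this same aromatic group: a step that the two limits leave unreadable from compound 1 to compound 2 and a step that the two limits leave unreadable from compound 1 to compound 3 and a step that the two limits leave unreadable from compound 2 to compound 3 are all that can be said of them. None has a readable size, and none gives a direction. The expectation for this assay rests on compound 3 with its limit of > 30000 nM and on the two steps that reach it, and no change beyond the scatter is expected. The expected size of a number no higher from compound 3 to compound 4 (the limit leaves the size open) is therefore estimated as none beyond the scatter. A further report of only a limit is the likeliest outcome. For compound 4 the estimate is 30000 nM with an expected range from 12000 nM to 50000 nM in this measurement.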

Compound 4, concentration for 50% growth inhibition: > 30000 nM
Compound 4 ended at the assay's limit; the forecaster's own chance of this, stated with the estimate: 75%; the middle value lies on the limit itself.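

In this assay compound 4 gives > 30000 nM, which is a limit of the assay and not a number. Its steps from compound 1, compound 2 and compound 3 therefore cannot be read, and all four compounds sit together: the limit of > 30000 nM in this assay, at which 4 of the 4 values shown sit.

The compounds shown leave open which change to the shared core, if any, would give a readable number in this assay.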